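Amide ring change on the benzylic amide of compound 3

The compounds below may be only part of what the source reports. "The series", "measured", "known", "first", "only" and "open" are said of these compounds alone.

compound 1 `CC(=O)NCc1cccc(Cn2nc(NS(=O)(=O)c3ccc(Cl)s3)c3c(F)cccc32)c1`: 79.4 nM
compound 2 `CC(=O)NCc1cccc(Cn2nc(NS(=O)(=O)c3ccc(Cl)s3)c3c(C(C)=O)cccc32)c1`: 100 nM
compound 3 `COc1cccc2c1c(NS(=O)(=O)c1ccc(Cl)s1)nn2Cc1cccc(CNC(=O)C2COC2)c1`: 20 nM

In a functional assay on CHO cells for antagonist activity at C-C chemokine receptor type 4 (Homo sapiens), read by GTPgammaS binding (on this read-out higher numbers stand for weaker inhibition and lower numbers for stronger inhibition), compound 3 stands lowest of the three numbers; compound 1 lies a measured distance above it and compound 2 further still, both beyond the scatter. Compound 4 `COc1cccc2c1c(NS(=O)(=O)c1ccc(Cl)s1)nn2Cc1cccc(CNC(=O)C2CCCO2)c1` differs from compound 3 by oxolan-2-yl in place of oxetan-3-yl on a carbonyl carbon. Among the compounds with values here, the only measured single step, a 1.3-fold higher number from compound 1 to compound 2 (0.10 log units; within the scatter), sits on the shared core rather than on the amide and therefore says nothing about this ring change. Within the data shown here, no measured step bears on it. With nothing to point either way, a step no larger than the scatter is expected, a 1.3-fold higher number from compound 3 to compound 4 (0.10 log units; within the scatter). Compound 4 is estimated at 25 nM, within 10 nM to 63 nM.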

Compound 4, half-maximal inhibitory concentration: 39.8 nM
Beside the measured number, compound 4's estimate is 1.6-fold (0.20 log units) below it; low and high end bracket the measured number.
By their numbers in this assay, from the lowest: compounds 3, 4, 1 and 2 (each within the scatter of the next, the first and the last beyond it).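

In this assay, oxolan-2-yl in place of oxetan-3-yl on the carbonyl carbon gives a 2.0-fold higher number from compound 3 to compound 4 (0.30 log units; within the scatter). Within the data shown here, this is the first measured step at the amide, and it shows that this position accepts the five-membered non-aromatic ring in place of the four-membered one with no change beyond the scatter. No available evidence bears on this result.

Compounds 1 and 2 differ from compound 3 in more than one place, so their steps to it cannot be read. Open, as far as these compounds go, is how a cyclopentyl ring, an oxan-4-yl ring or a plain acetyl group on this amide would read on the core of compound 3.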